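Removing a methyl from a thiosemicarbazone: a small step

The source may report more compounds than this note shows. Statements on the series, on what has been measured and on what is new or still open speak of the compounds shown alone.

Of the compounds shown here, two of a shared core have been tested in a functional assay on A-431 cells (Homo sapiens) for cytotoxicity, read by MTT assay, with a stated time of 72 h, tested at 10 uM; a lower number here means less inhibition of growth, a higher number more inhibition of growth at the concentration tested. Compound 1 `N/C(=N\NC(=S)N1CCOCC1)c1ccccn1` gives 69.4% in this assay. Compound 2 `Cc1ccnc(/C(N)=N/NC(=S)N2CCSCC2)c1` gives 60% in this assay, and the gap between compound 2 and compound 1 lies within the usual scatter of such measurements, so the two numbers cannot be told apart. Compound 3 `N/C(=N\NC(=S)N1CCSCC1)c1ccccn1` has not yet been measured. It differs from compound 2 in one place only: hydrogen in place of methyl on an aromatic carbon, on a six-membered aromatic ring with one nitrogen, meta to a large group and opposite the ring nitrogen. Among the compounds with values here, no measured pair shows what such a change does here, so the expectation rests on the change being small. The step of a number 2 percentage points higher from compound 2 to compound 3 (within the scatter) is expected to stay within the scatter, in no clear direction. Compound 3 is therefore estimated at 62%, with a range from 46% to 78%.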

Compound 3, percent growth inhibition at one concentration: 61.4%
Compound 3: the middle estimate sits 0.6 percentage points above what was measured, and the stated range covers the measured number.
By their numbers in this assay, from the lowest: compounds 2, 3 and 1 (each within the scatter of the next).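

In this assay, a number a number 1.4 percentage points higher from compound 2 to compound 3 (within the scatter) comes with hydrogen in place of methyl on an aromatic carbon, so this position, meta to a large group and opposite the ring nitrogen, now has one measured change, and that change cannot be told from scatter. The other new pair, a number a number 8 percentage points lower from compound 1 to compound 3 (within the scatter) with thiomorpholin-4-yl in place of morpholin-4-yl on a thiocarbonyl carbon, shows that this swap also cannot be told from scatter at the one concentration tested. Nothing measured here explains either step.

On these data alone, whether a different group on this aromatic carbon, such as an amine, a carboxylic acid or a longer chain, would give a step beyond the scatter remains open. The same holds for replacing thiomorpholin-4-yl with an open-chain amine on the thiocarbonyl carbon.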